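This account rests on a few compounds, and the source may have more. Where it says the series, first, only, none or still open, it means among the compounds named here.

Measured so far in an ADME assay on NIH3T3 cells (Mus musculus) for cytotoxicity, read by MTT assay, with a stated time of 72 h; a lower number here means a stronger inhibitor, a higher number a weaker inhibitor:

Compound 1 `C#CCn1cc(C(=O)NC(CC(=O)Nc2ccccc2)c2ccccc2)c(=O)c2cc(F)c(Cl)nc21` gives 9700 nM.
Compound 2 `C#CCn1cc(C(=O)NC(CC(=O)Nc2ccccn2)c2ccccc2)c(=O)c2ccc(Cl)nc21` is reported as "not active" (no number reported), with no number.
Compound 3 `C#CCn1cc(C(=O)NC(CC(=O)NC2CCCCC2)c2ccccc2)c(=O)c2cc(F)c(Cl)nc21` is reported as "not active" (no number reported), with no number.

Compound 2 stands without a number: of the three compounds tested, only compound 1 yields a half-maximal inhibitory concentration at all, and that one is weak. Compound 2 and compound 3 share the outcome of no reported value, so nothing separates them on the numbers shown.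

The step from compound 2 to compound 4 `C#CCn1cc(C(=O)NC(CC(=O)Nc2ccccc2)c2ccccc2)c(=O)c2ccc(Cl)nc21` is a single change: phenyl in place of pyridin-2-yl on an amide-type nitrogen. Everything else in the molecule stays the same, so the comparison isolates that one swap.

For the measured compounds named here, no measured pair makes this exact step, so its size cannot be read from the data. Compound 1 carries the same phenyl amide as compound 4, and because compound 1 gives 9700 nM a weak but measurable number seems possible for compound 4 as well. At the same time, both compounds without a phenyl amide gave no number, and compound 4 may also fall outside the measurable range.

Compound 4 is therefore expected to come in around 15000 nM, with a plausible range from 5000 nM to 50000 nM.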

Compound 4, half-maximal inhibitory concentration: 4400 nM
Compound 4: middle estimate off by 3.4-fold (0.53 log units), on the high side, outside the stated range (below it).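

In this assay compound 4, with phenyl on the amide-type nitrogen, gives 4400 nM as a number, whereas compound 2, with pyridin-2-yl at that place, is reported as "not active"; compound 2 has no number, and the size of this swap cannot be read. The change elsewhere in the molecule, hydrogen in place of fluoro on an aromatic carbon, does have a readable size: there is a 2.2-fold lower number from compound 1 to compound 4 (0.34 log units; beyond the scatter), a modest step that gives the series its first measured comparison between two compounds differing in one place. No measurement shown here explains either the appearance of a number with phenyl or the shift on losing fluoro.

On these data alone, whether pyridin-3-yl or a methoxy-bearing phenyl on the same amide-type nitrogen would give a number remains open. As far as these compounds go, it is also open whether a chloro or methyl group on the aromatic carbon that holds fluoro in compound 1 would move the number, and whether the fluoro-to-hydrogen step would hold with groups other than phenyl on that nitrogen.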